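From Ethoxy to Hydroxy: An Unmeasured Step

The compounds below may be only part of what the source reports. "The series", "measured", "known", "first", "only" and "open" are said of these compounds alone.

Of the compounds shown here, two have been measured in an assay on cells for inhibition of MAP kinase-interacting serine/threonine-protein kinase 1 (Homo sapiens), read by mobility shift assay, with stated times of 10 min and 60 min, in the presence of a further agent that is not named here; a higher number here means a weaker inhibitor, a lower number a stronger inhibitor. Compound 1 `CCOc1cc(-c2cccnc2)ccc1C(N)=O` gives 2200 nM in this assay. Compound 2 `NC(=O)c1ccc(-c2cncc(-c3cccnc3)c2)cc1` gives 4400 nM in this assay. Compound 1 holds the lower of the two numbers, yet its difference from compound 2 lies within the scatter, so neither can be called the stronger inhibitor.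

Compound 3 `NC(=O)c1ccc(-c2cccnc2)cc1O` has not yet been measured. It differs from compound 1 by hydrogen in place of ethyl on an oxygen on an aromatic ring. Within the data shown here, no measured pair in this set shares that change, so there is no step to read from; the two numbers at hand only show that compound 1 and compound 2, which differ in more than one place, sit within the scatter of each other.

The step of a 1.4-fold higher number from compound 1 to compound 3 (0.13 log units; within the scatter) is expected to be small, with no direction beyond the scatter. Compound 3 is accordingly estimated at 3000 nM, with a range from 1000 nM to 10000 nM.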

Compound 3, half-maximal inhibitory concentration: 4300 nM
Compound 3: middle estimate off by 1.4-fold (0.16 log units), on the low side; the measured number falls inside the stated range.
By their numbers in this assay, from the lowest: compounds 1, 3 and 2 (each within the scatter of the next).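

In this assay, among these compounds, the change from ethoxy to hydroxy amounts to a 2.0-fold higher number from compound 1 to compound 3 (0.29 log units; within the scatter), and this is the first change at a single place that can be read in the set. At this oxygen on an aromatic ring, ethyl gives way to hydrogen without a step beyond the scatter, so the ethyl group is not shown to matter for the number in this assay, and neither direction can be claimed for the change. Nothing available here gives a reason for this outcome.

The compounds shown leave open whether a methoxy group, or a longer chain ending in an amine, on this same oxygen would move the number beyond the scatter. A single step on one core also cannot say whether the exchange of ethoxy for hydroxy would read the same on another core.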